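Phenylethenyl in place of phenylethynyl on two cores

This account rests on a few compounds, and the source may have more. Where it says the series, first, only, none or still open, it means among the compounds named here.

Of the compounds shown here, three have been measured in a functional assay on K562 cells (Homo sapiens) for inhibition, read by thymidine incorporation, with a stated time of 48 h, tested at 10 ug/mL (a higher number here means more inhibition at the concentration tested (going by the name of the read-out), a lower number less inhibition), and a fourth has not. Compound 1 `C(#Cc1nc(-c2ccccc2)nc2c1ncn2Cc1ccccc1)c1ccccc1` and compound 3 `C(=C/c1nc(-c2ccccc2)nc2c1ncn2Cc1ccccc1)\c1ccccc1` share one core; compound 2 `OC[C@H]1OC(n2cnc3c(C#Cc4ccccc4)ncnc32)[C@H](O)[C@@H]1O` and the unmeasured compound 4 `OC[C@H]1OC(n2cnc3c(/C=C/c4ccccc4)ncnc32)[C@H](O)[C@@H]1O` share another. The difference between the two cores is not broken down here.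

In this assay compound 1 gives 100%, and compound 2 gives 100%, level with compound 1 at the digits recorded and within the scatter of it. Compound 3, in this assay, gives 34%. Going by the values given here, the one change from compound 1 to compound 3 is 2-phenylethenyl in place of 2-phenylethynyl on an aromatic carbon, and it made the step of a number 66 percentage points lower from compound 1 to compound 3 (beyond the scatter).

The change from compound 2 to compound 4 is 2-phenylethenyl in place of 2-phenylethynyl on an aromatic carbon. It is the same kind of change, at a place described in nearly the same words; what differs around the place is that in compound 1 the carbon is also meta to a phenyl group (6 heavy atoms), while in compound 2 it is not. Level with compound 1, compound 2 starts at 100%, and the same kind of change made the step of a number 66 percentage points lower from compound 1 to compound 3 (beyond the scatter). A step of similar size is therefore expected, estimated as a number 62 percentage points lower from compound 2 to compound 4 (beyond the scatter) in this assay. Compound 4 is therefore expected to give about 38% in this assay, likely between 15% and 70%.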

Compound 4, a percentage reported as inhibition, at one concentration (the size of the read-out at that concentration, not a potency): 79%
The estimate for compound 4 lay 41 percentage points below the measured number, and the stated range ends below it.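

Carried to the second core, the replacement of 2-phenylethynyl by 2-phenylethenyl again lowers the number in this assay, and the step there is a number 21 percentage points lower from compound 2 to compound 4 (beyond the scatter), so the direction of the change is shared by both pairs of compounds. Its size, however, does not carry over unchanged from one core to the other: the same change on two cores in this assay, a number 66 percentage points lower (beyond the scatter) from compound 1 to compound 3 and a number 21 percentage points lower (beyond the scatter) from compound 2 to compound 4, 45 percentage points apart, beyond the scatter of two such steps

This shows that the size of the step depends on the core in these two pairs, but it does not show which of the differences between the cores sets that size, and two pairs are too few to support a rule for the series; as each number is a reading at one concentration, the comparison also says nothing about potency.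

The compounds shown leave open whether the step would keep its direction with a saturated 2-phenylethyl chain in the same place, or with an amine or a carboxylic acid on the phenyl ring of the side chain. They also leave open how large the step would be on a third core, and whether it would follow either of the two pairs seen here.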